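A few compounds are considered here, and "the series" means these few. Any claim that something is new, unique, unknown or untested is made for them only; others in the source may bear on it.

In an assay for positive allosteric modulation of metabotropic glutamate receptor 3 (Rattus norvegicus) (a higher number here means that more compound is needed for the effect, a lower number that less compound is needed), compound 1 `Cc1ncc(OCCCCOc2ccc(C(=O)CC(C)(C)C)c(O)c2C)cc1C(=O)O` gives 79 nM, while compound 2 `COc1ccc(C(=O)O)cc1OC[C@@H](C)COc1ccc(C(=O)CC(C)(C)C)c(O)c1C` gives 1040 nM, the higher of the two numbers, a gap that lies beyond the usual scatter. Compound 3 `COc1ccc(C(=O)O)cc1OC[C@H](C)COc1ccc(C(=O)CC(C)(C)C)c(O)c1C` has not yet been measured in this assay. Between compound 2 and compound 3 (the two compounds have the same atoms and bonds and differ only in configuration as drawn: 1 of 1 stereo elements differ; a stereocentre at a saturated chain carbon is drawn S in compound 2 and R in compound 3); the two compounds have the same atoms and bonds and differ only in configuration as drawn. Within the data shown here, no measured pair here shows what such a change does, so the step from compound 2 to compound 3 is expected to be a 1.3-fold lower number from compound 2 to compound 3 (0.11 log units; within the scatter), in either direction. For compound 3 the estimate in this assay is 800 nM, with a range from 200 nM to 4000 nM.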

Compound 3, half-maximal effective concentration: 384 nM
The estimate for compound 3 lay 2.1-fold (0.32 log units) above the measured number, and the stated range covers the measured number.
By their numbers in this assay, from the lowest: compound 1; then compound 3; then compound 2.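

In this assay, inverting the stereocentre at the saturated chain carbon from S to R gives a 2.7-fold lower number from compound 2 to compound 3 (0.43 log units; beyond the scatter), the first measured sign that configuration matters at this position. The effect is modest, but it lies beyond the usual scatter. It can be assigned to this stereocentre alone because nothing else changes: the fact that compounds 2 and 3 differ only in the configuration as drawn

The compounds shown leave open whether the R form would keep its lower number with an ethyl group or a hydroxyl group on that chain carbon. Whether a stereocentre would matter similarly in the chain of compound 1 is also unknown.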